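Replacing the 4-fluorophenoxy group with cyclohexylmethyl

The compounds below may be only part of what the source reports. "The series", "measured", "known", "first", "only" and "open" are said of these compounds alone.

Measured compounds:
- Compound 1, `COc1ccc(F)cc1CNCCCNc1ccnc2cc(C3CCCCC3)ccc12`: 4200 nM
- Compound 2, `COc1ccc(F)cc1CNCCCNc1ccnc2cc(Cc3ccccc3)ccc12`: 4200 nM
- Compound 3, `COc1ccc(F)cc1CNCCCNc1ccnc2cc(Oc3ccc(F)cc3)ccc12`: 14500 nM

In a physicochemical assay for solubility, with a stated time of 18 h, at pH 7.4 (on this read-out lower numbers stand for lower solubility and higher numbers for higher solubility), compound 3 gives the highest number of the three, with compound 1 and compound 2 both sitting at the same lower level. Compound 4, `COc1ccc(F)cc1CNCCCNc1ccnc2cc(CC3CCCCC3)ccc12`, has not yet been measured. Its change from compound 3 is cyclohexylmethyl in place of 4-fluorophenoxy on an aromatic carbon. Within the data shown here, two measured steps bear on this: a 3.5-fold higher number from compound 1 to compound 3 (0.54 log units; beyond the scatter) and a 3.5-fold higher number from compound 2 to compound 3 (0.54 log units; beyond the scatter). Both steps move in the opposite direction to the one now taken, since in each case the 4-fluorophenoxy group enters, whereas for compound 4 it leaves. A step of similar size in this assay is therefore expected, but downward, bringing compound 4 back toward the level of compound 1 and compound 2. Compound 4 is accordingly expected to give 3000 nM, within a range from 1000 nM to 9000 nM, which corresponds to an expected step of a 4.8-fold lower number from compound 3 to compound 4 (0.68 log units; beyond the scatter).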

Compound 4, solubility: 4200 nM
Compound 4: middle estimate off by 1.4-fold (0.15 log units), on the low side, and the stated range covers the measured number.
By their numbers in this assay, from the lowest: compounds 1, 2 and 4 (each within the scatter of the next); then compound 3.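

In this assay, replacing 4-fluorophenoxy with cyclohexylmethyl gives a 3.5-fold lower number from compound 3 to compound 4 (0.54 log units; beyond the scatter), so a fully carbon group with a non-aromatic ring behaves here like the other two carbon groups. Compound 1 and compound 2 differ in two features at once, the saturated chain carbon and the ring type, and compound 4 separates them: adding that chain carbon to cyclohexyl gives no change at the digits printed from compound 1 to compound 4 (within the scatter), while cyclohexyl in place of phenyl on it gives no change at the digits printed from compound 2 to compound 4 (within the scatter). Of these four compounds, only compound 3 stands apart.

Nothing shown explains why the 4-fluorophenoxy compound differs. Going by these compounds, it also remains open whether its oxygen, its fluorine or both matter, which an unsubstituted phenoxy or a cyclohexyloxy group at this position could begin to separate.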